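Removing a Hydroxy Group from the Most Active Compound

The compounds below may be only part of what the source reports. "The series", "measured", "known", "first", "only" and "open" are said of these compounds alone.

Measured compounds:
Compound 1 `COc1ccc(/C=C/C(=O)O)cc1OC(=O)c1nc(C)c(C)nc1C` gives 216%
Compound 2 `CCOC(=O)/C=C/c1ccc(OC(=O)c2nc(C)c(C)nc2C)c(O)c1` gives 375%

Both numbers come from a functional assay on EA.hy 926 cells (Homo sapiens) for cytotoxicity, read by MTT assay, with stated times of 24 h and 12 h, tested at 100 uM; a lower number here means a weaker effect, a higher number a stronger effect of the compound at the concentration tested. Compound 2 stands highest of the two; compound 1 is the nearest, and its value lies far enough below that the gap is beyond the usual scatter. Among the measured compounds shown here, the two structures differ in more than one place, so no single step links them.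

Compound 3 `CCOC(=O)/C=C/c1ccc(OC(=O)c2nc(C)c(C)nc2C)cc1` has not yet been measured. It differs from compound 2 in one place: hydrogen in place of hydroxy on an aromatic carbon. Compound 1, which also carries no free hydroxy, shows in this assay a weaker effect than compound 2, but it differs in other ways as well, so this gives only a loose hint. A downward step is expected, of moderate size, as a number 105 percentage points lower from compound 2 to compound 3 (beyond the scatter). Compound 3 is therefore estimated at 270%, within a range from 150% to 400%.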

Compound 3, a percentage reported as activity, at one concentration (the size of the read-out at that concentration, not a potency): 96.1%
Compound 3: middle estimate off by 173.9 percentage points, on the high side; the measured number lies below the stated range.
By their numbers in this assay, from the lowest: compound 3; then compound 1; then compound 2.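

Among the compounds shown here, this is the first comparison in which only one place changes. In this assay, putting hydrogen in place of hydroxy on this aromatic carbon, ortho to a large group, gives a number 278.9 percentage points lower from compound 2 to compound 3 (beyond the scatter). Compound 1 and compound 2 differ in more than one place, so they could not isolate this position, whereas this single change shows that the read-out at this concentration depends strongly on what sits there, at least for this pair. No measurement shown here accounts for the size of this drop.

On these data alone, what remains open is whether the hydroxy itself is needed, or whether another group on the same carbon, such as an amine or a fluorine atom, would keep the read-out high. As far as these compounds go, it is also open whether a similar step would appear if a longer chain replaced the ethyl of the ester.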